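The compounds below may be only part of what the source reports. "The series", "measured", "known", "first", "only" and "open" are said of these compounds alone.

Measured so far:
compound 1, `CCc1ccc2nc(NC(=O)C3CC3)sc2c1`: > 50000 nM
compound 2, `O=C(Nc1nc2ccc(F)cc2s1)C1CC1`: > 50000 nM

In an ADME assay on H9c2 cells (Rattus norvegicus) for cytotoxicity (on this read-out higher numbers stand for weaker inhibition and lower numbers for stronger inhibition), compound 1 gives > 50000 nM, which is a limit of the assay rather than a number. In this assay compound 2 gives > 50000 nM, also a limit. Compound 2 thus stands at the limit of > 50000 nM in this assay, at which 2 of the 2 values shown sit. Going by the values given here, the only measured step, a step that the two limits leave unreadable from compound 1 to compound 2, cannot be read from its two limits. Compound 3, `O=C(Nc1nc2ccc([N+](=O)[O-])cc2s1)C1CC1`, differs from compound 2 as nitro in place of fluoro on an aromatic carbon. Among the compounds with values here, no measured step bears on this change, and the two limits give nothing to compare it with, so the expectation is that compound 3 stays at the limit, with a step of a number no higher from compound 2 to compound 3 (the limit leaves the size open) in this assay of no readable size. Compound 3 is estimated at 50000 nM, within 20000 nM to 100000 nM, most likely reported only as a limit.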

Compound 3, half-maximal inhibitory concentration: > 50000 nM
Compound 3 ended at the assay's limit (the forecaster's own chance of this, stated with the estimate: 80%); the middle value sits exactly at the limit.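

Going by these compounds alone, compound 3 also gives a limit and not a number, so no step among compound 1, compound 2 and compound 3 can be read: the limit of > 50000 nM in this assay, at which 3 of the 3 values shown sit. As far as these compounds go, whether any group at this place on the shared core would give a readable value in this assay stays open.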